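This account rests on a few compounds, and the source may have more. Where it says the series, first, only, none or still open, it means among the compounds named here.

In a functional assay on DU-145 cells (Homo sapiens) for inhibition, read by trypan blue exclusion, with a stated time of 96 h (a lower number here means a stronger inhibitor of growth, a higher number a weaker inhibitor of growth), compound 3 (`COc1ccc(/C=C(/SCc2ccc(F)cc2)C(=O)c2ccc(C(=O)O)cc2)cc1O`) gives 10000 nM, level with compound 1 (`CN(C)c1ccc(/C=C(/SCc2ccc(F)cc2)C(=O)c2ccc(C(=O)O)cc2)cc1`) at 10000 nM. Compound 2 (`O=C(O)c1ccc(C(=O)/C(=C\c2ccc(O)c([N+](=O)[O-])c2)SCc2ccc(F)cc2)cc1`) gives > 100000 nM, which is a limit of the assay. Compound 4 (`Nc1ccc(/C=C(/SCc2ccc(F)cc2)C(=O)c2ccc(C(=O)O)cc2)cc1[N+](=O)[O-]`) differs from compound 3 as follows: 4-amino-3-nitrophenyl in place of 3-hydroxy-4-methoxyphenyl on a double-bonded chain carbon bound to a double-bonded chain carbon. Its 4-amino-3-nitrophenyl group shares the nitro group of the 4-hydroxy-3-nitrophenyl in compound 2, and two measured steps bear on that: an at least 10-fold lower number from compound 2 to compound 3 (1.00 log units; beyond the scatter) and an at least 10-fold higher number from compound 1 to compound 2 (1.00 log units; beyond the scatter). Against these stands no change at the digits printed from compound 1 to compound 3 (within the scatter), which shows that compound 1, with its 4-(dimethylamino)phenyl, matches compound 3. A higher number, though a smaller step than those to the limit, is therefore expected, the estimated step being a 3.0-fold higher number from compound 3 to compound 4 (0.48 log units; beyond the scatter). The estimated value for compound 4 is 30000 nM, with an expected range of 8000 nM to 100000 nM.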

Compound 4, concentration for 50% growth inhibition: 10000 nM
Compound 4: the middle estimate sits 3.0-fold (0.48 log units) above what was measured, and the stated range covers the measured number.
By their numbers in this assay, from the lowest: compounds 1, 3 and 4 (each within the scatter of the next). At a limit, above all of these: compound 2.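

With amino in place of hydroxy on an aromatic carbon, the result is an at least 10-fold lower number from compound 2 to compound 4 (1.00 log units; beyond the scatter), so a nitro group on this aryl group does not by itself go with the weak growth inhibition of compound 2. The figure for compound 2 is a limit: the limit of > 100000 nM in this assay, at which 1 of the 4 values shown sits. At this place, on a double-bonded chain carbon, 4-amino-3-nitrophenyl matches both other groups, with no change at the digits printed from compound 3 to compound 4 (within the scatter) and no change at the digits printed from compound 1 to compound 4 (within the scatter).

On these data alone, what an unsubstituted phenyl or a 4-aminophenyl without the nitro group would give here remains open. So does whether any group at this place can bring the number below the level shared by compound 1, compound 3 and compound 4.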